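The compounds below may be only part of what the source reports. "The series", "measured", "known", "first", "only" and "open" are said of these compounds alone.

Working notes on the series, step from compound 1 to compound 3.

Compound 1 `Cc1cc(C)c(C(=O)N[C@@H](CNC(=O)CO[C@@H]2C[C@@H](CNc3ccccn3)N(C(=O)OCc3ccccc3)C2)C(=O)O)c(C)c1` serves as the anchor. In an assay on a protein complex for inhibition of integrin alpha-5/beta-1 (Homo sapiens), read by ELISA (on this read-out higher numbers stand for weaker inhibition and lower numbers for stronger inhibition), compound 1 gives 3.5 nM. Within the data shown here, its only measured neighbour is compound 2 `COc1ccnc(NC[C@@H]2C[C@@H](OCC(=O)NC[C@H](NC(=O)c3c(C)cc(C)cc3C)C(=O)O)CN2C(=O)OCc2ccccc2)c1`, which in this assay gives 0.54 nM; that pair is joined by a single change, methoxy in place of hydrogen on an aromatic carbon, and the step of a 6.5-fold lower number from compound 1 to compound 2 (0.81 log units; beyond the scatter) is the only one recorded. Among the measured compounds shown here, of the two numbers known so far, compound 1 therefore holds the higher one.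

Compound 3 `O=C(CO[C@@H]1C[C@@H](CNc2ccccn2)N(C(=O)OCc2ccccc2)C1)NC[C@H](NS(=O)(=O)c1ccccc1)C(=O)O` is not yet measured. It differs from compound 1 by phenylsulfonyl in place of (2,4,6-trimethylphenyl)carbonyl on an amine nitrogen. For the measured compounds named here, no measured step touches this part of the molecule: the one recorded step alters a substituent on an aromatic carbon and leaves the amine cap unchanged, so it offers no guide here. Because the exchange replaces more of the structure than the step of a 6.5-fold lower number from compound 1 to compound 2 (0.81 log units; beyond the scatter) did, a move beyond the scatter is expected, and in the absence of any precedent for the sulfonyl cap it is expected to run toward weaker inhibition, about an 8.6-fold higher number from compound 1 to compound 3 (0.93 log units; beyond the scatter). For compound 3 the estimate is 30 nM, with a range of 5 nM to 200 nM.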

Compound 3, half-maximal inhibitory concentration: 86 nM
For compound 3 the middle estimate is 2.9-fold (0.46 log units) below the measured one; measured number inside the range.
By their numbers in this assay, from the lowest: compound 2; then compound 1; then compound 3.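

Among these compounds, the amine cap is the first position seen to move this assay strongly against inhibition, with a 25-fold higher number from compound 1 to compound 3 (1.39 log units; beyond the scatter) running opposite in direction to a 6.5-fold lower number from compound 1 to compound 2 (0.81 log units; beyond the scatter) on the aromatic carbon. Among the compounds shown here, this shows that the amine nitrogen is sensitive to the choice of cap, and that phenylsulfonyl is a clearly poorer cap than (2,4,6-trimethylphenyl)carbonyl in the only pair compared at this position. Nothing available bears on why the exchange has this effect.

The exchange alters the linking group and the ring substitution together, so this single step cannot separate the two: an unsubstituted benzoyl cap and a (2,4,6-trimethylphenyl)sulfonyl cap on the same amine nitrogen would each vary one of them alone. Also open, from the compounds shown here alone, is whether the methoxy substituent on the aromatic carbon, which lowers the number under the (2,4,6-trimethylphenyl)carbonyl cap, gives a similar step when it is combined with phenylsulfonyl.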